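Replacing tert-butoxy with methyl on the carbonyl carbon

The source may report more compounds than this note shows. Statements on the series, on what has been measured and on what is new or still open speak of the compounds shown alone.

Measured compounds:
compound 1 `COC(=O)C1=C(C)NC(=O)NC1c1ccoc1`: 2%
compound 2 `CC1=C(C(=O)OCC(C)C)C(c2ccoc2)NC(=O)N1`: 16%
compound 3 `CC1=C(C(=O)OC(C)(C)C)C(c2ccoc2)NC(=O)N1`: 2%

In an assay on membranes from HeLa cells for displacement of a labelled ligand from adenosine receptor A3 (Homo sapiens), read by scintillation counting, with a stated time of 180 min, tested at 1 uM (on this read-out higher numbers stand for more inhibition at the one concentration tested (going by the name of the read-out) and lower numbers for less inhibition), compound 3 sits level with compound 1, the two lowest of the three numbers, while compound 2 stands higher. The steps show no change at the digits printed from compound 1 to compound 3 (within the scatter) and a number 14 percentage points lower from compound 2 to compound 3 (beyond the scatter). Compound 4 `CC(=O)C1=C(C)NC(=O)NC1c1ccoc1` differs from compound 3 by methyl in place of tert-butoxy on a carbonyl carbon. Going by the values given here, the measured steps all change the group on the oxygen of the ester, none touches the carbonyl carbon itself, so they bear on this change only loosely; the one step beyond the scatter was modest and left compound 3 low. A small shift is therefore expected, most likely none beyond the scatter. Compound 4 is estimated at 6%, ranging from 0% to 22%. That expected step is a number 4 percentage points higher from compound 3 to compound 4 (within the scatter).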

Compound 4, a percentage reported as inhibition, at one concentration (the size of the read-out at that concentration, not a potency): 2%
Compound 4: middle estimate off by 4 percentage points, on the high side; measured number inside the range.
By their numbers in this assay, from the lowest: compounds 1, 3 and 4 (each within the scatter of the next); then compound 2.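

Going by these compounds alone, changing the carbonyl carbon itself, which the earlier steps left alone, gives no change at the digits printed from compound 3 to compound 4 (within the scatter) and no change at the digits printed from compound 1 to compound 4 (within the scatter) and so leaves a methyl group there at the same low level as the methyl and tert-butyl esters. Isobutoxy is the only group here that stands apart, with a number 14 percentage points lower from compound 2 to compound 4 (beyond the scatter) as the step that sets it off from methyl. Nothing available explains these numbers. Compounds 1, 3 and 4 sit so low that any further loss could hardly show. Going by these compounds, whether an amide, a carboxylic acid or a longer chain on the carbonyl carbon would exceed compound 2 stays open.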